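A few compounds are considered here, and "the series" means these few. Any claim that something is new, unique, unknown or untested is made for them only; others in the source may bear on it.

Measured in a functional assay on NCI/ADR-RES cells (Homo sapiens) for inhibition, read by sulforhodamine B assay, with a stated time of 48 h; on this read-out higher numbers stand for weaker inhibition of growth and lower numbers for stronger inhibition of growth:
- Compound 1 `O=C(Nc1cccc(-n2cc(-c3ccncc3)c(-c3ccc(Cl)c(O)c3)n2)c1)Nc1cccc(C(F)(F)F)c1` gives > 32500 nM (a limit, not a number)
- Compound 2 `COc1cc(-c2nn(-c3cccc(NC(=O)Nc4cc(C(F)(F)F)cc(C(F)(F)F)c4)c3)cc2-c2ccncc2)ccc1Cl` gives 5180 nM
- Compound 3 `COc1cc(-c2nn(-c3cccc(NC(=O)Nc4ccc(Cl)c(Cl)c4)c3)cc2-c2ccncc2)ccc1Cl` gives 4670 nM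

Compound 1 has no exact value and stands only at a limit: the limit of > 32500 nM in this assay, at which 1 of the 3 values shown sits. Compound 4 `O=C(Nc1cccc(-n2cc(-c3ccncc3)c(-c3ccc(Cl)c(O)c3)n2)c1)Nc1ccc(Cl)c(Cl)c1` has 3,4-dichlorophenyl in place of 3-(trifluoromethyl)phenyl on an amide-type nitrogen. Compound 3 also carries 3,4-dichlorophenyl and gives 4670 nM, which suggests that a measurable number is possible with this group. A moderate expected step of an at least 2.1-fold lower number from compound 1 to compound 4 (0.33 log units; beyond the scatter) would therefore point towards stronger inhibition of growth, although compound 4 may still reach the limit of this assay. The estimate for compound 4 is 15000 nM, with an expected range of 4500 nM to 32500 nM.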

Compound 4, concentration for total growth inhibition: > 32500 nM
Compound 4 ended at the assay's limit; the forecaster's own chance of this, stated with the estimate: 35%; at least 2.1-fold (0.33 log units) between middle value and limit.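

With 3,4-dichlorophenyl held constant, hydrogen in place of methyl on an oxygen on an aromatic ring gives an at least 6.9-fold higher number from compound 3 to compound 4 (0.84 log units; beyond the scatter), meaning weaker inhibition of growth. The 3,4-dichlorophenyl group alone is therefore not enough to give compound 4 a measurable number. The step between compound 1 and compound 4 cannot be read, since both values are limits: the limit of > 32500 nM in this assay, at which 2 of the 4 values shown sit.

Still open, from the compounds shown here alone, is whether a longer chain, such as ethyl, on that oxygen would keep the growth inhibition seen with methyl. Also open, going by these compounds, is how an amine at that place would behave.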